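The source may report more compounds than this note shows. Statements on the series, on what has been measured and on what is new or still open speak of the compounds shown alone.

In a functional assay on DU-145 cells (Homo sapiens) for cytotoxicity, read by MTT assay, with a stated time of 24 h (a lower number here means a stronger inhibitor, a higher number a weaker inhibitor), compound 1 `O=C1/C(=C/c2ccccc2F)CN(Cc2cn(Cc3ccccc3F)nn2)C/C1=C\c1ccccc1F` gives 10600 nM as its reading. Compound 2 `Cc1ccc(/C=C2\CN(C(=S)SCc3cn(Cc4ccc(F)cc4)nn3)C/C(=C\c3ccc(C)cc3)C2=O)cc1` gives 38800 nM and compound 3 `O=C1/C(=C/c2ccccc2F)CN(C(=S)SCc2cn(Cc3ccc(F)cc3)nn2)C/C1=C\c1ccccc1F` gives 35700 nM as theirs, so compound 1 holds the lowest number of the three, with both gaps beyond the usual scatter. Compound 4 `O=C1/C(=C/c2ccccc2F)CN(Cc2cn(Cc3ccccc3Cl)nn2)C/C1=C\c1ccccc1F` keeps the core of compound 1 and changes in one place: chloro in place of fluoro on an aromatic carbon with chloro in place of fluoro on an aromatic carbon, ortho to a large group, turning 2-fluorobenzyl into 2-chlorobenzyl. Among the compounds with values here, no measured pair shows this swap. With compound 1 at 10600 nM as the closest guide, no shift beyond the scatter is expected, in either direction. The estimate means a 1.1-fold lower number from compound 1 to compound 4 (0.03 log units; within the scatter) as the expected step. For compound 4 the estimate is 10000 nM with 4500 nM to 22000 nM as its expected range.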

Compound 4, half-maximal inhibitory concentration: 7500 nM
The estimate for compound 4 lay 1.3-fold (0.12 log units) above the measured number; the measured number falls inside the stated range.
By their numbers in this assay, from the lowest: compounds 4 and 1 (each within the scatter of the next); then compounds 3 and 2 (each within the scatter of the next).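

In this assay, 2-chlorobenzyl in place of 2-fluorobenzyl gives a 1.4-fold lower number from compound 1 to compound 4 (0.15 log units; within the scatter) and so stays within the scatter: on this aromatic carbon, ortho to a large group, chloro and fluoro cannot be told apart. This pair is the only one shown that tests this position with the rest of the molecule held fixed. No measurement offers a reason for this result. As far as these compounds go, whether a methoxy group, a trifluoromethyl group, an amine or plain hydrogen at this position would keep the reading within the scatter stays open. So does whether the same swap reads alike on the other aromatic rings.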